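Fluorophenyl amide weighed against alkylphenyl analogues

A few compounds are considered here, and "the series" means these few. Any claim that something is new, unique, unknown or untested is made for them only; others in the source may bear on it.

Compound 1, `CCc1ccc(NC(=O)C2CCN(C/C=C/c3ccccc3)CC2)cc1`: 19600 nM
Compound 2, `CC(C)c1ccc(NC(=O)C2CCN(C/C=C/c3ccccc3)CC2)cc1`: 9430 nM
Compound 3, `COc1ccccc1NC(=O)C1CCN(C/C=C/c2ccccc2)CC1`: a limit of the assay, > 100000 nM

The three amides share one core and were read in a functional assay on A549 cells (Homo sapiens) for inhibition, read by MTT assay, with a stated time of 72 h; on this read-out lower numbers stand for stronger inhibition and higher numbers for weaker inhibition. Of the two numbers given, compound 1 holds the highest, its nearest neighbour being reached through a 2.1-fold lower number from compound 1 to compound 2 (0.32 log units; beyond the scatter). Compound 3 reports only a limit (the limit of > 100000 nM in this assay, at which 1 of the 3 values shown sits). Compound 4, `O=C(Nc1cccc(F)c1)C1CCN(C/C=C/c2ccccc2)CC1`, differs from compound 1 by 3-fluorophenyl in place of 4-ethylphenyl on an amide-type nitrogen. Within the data shown here, two measured steps bear on this: a 2.1-fold lower number from compound 1 to compound 2 (0.32 log units; beyond the scatter), where a larger alkyl on the aromatic ring lowered the number, and an at least 5.1-fold higher number from compound 1 to compound 3 (0.70 log units; beyond the scatter), where the 4-ethylphenyl gave way to another ring and the number rose. Compound 4 likewise loses the 4-ethylphenyl, so a higher number beyond the scatter is expected in this assay. For compound 4 the estimate is 45000 nM, ranging from 15000 nM to 130000 nM. That amounts to an expected 2.3-fold higher number from compound 1 to compound 4 (0.36 log units; beyond the scatter).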

Compound 4, half-maximal inhibitory concentration: 43300 nM
For compound 4 the middle estimate is 1.0-fold (0.02 log units) above the measured one, and the stated range covers the measured number.
By their numbers in this assay, from the lowest: compound 2; then compound 1; then compound 4. At a limit, above all of these: compound 3.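

In this assay, the 3-fluorophenyl amide reads weaker than both alkylphenyl amides, with a 2.2-fold higher number from compound 1 to compound 4 (0.34 log units; beyond the scatter) and a 4.6-fold higher number from compound 2 to compound 4 (0.66 log units; beyond the scatter). Even so, this position tolerates a ring without an alkyl group and still gives a measurable number, with an at least 2.3-fold lower number from compound 3 to compound 4 (0.36 log units; beyond the scatter). That last step rests on a limit of the assay for compound 3: the limit of > 100000 nM in this assay, at which 1 of the 4 values shown sits.

The compounds shown leave open whether the rise from compound 1 comes with the fluorine itself or with the loss of the ethyl group. On these data alone, how a chlorine or a tert-butyl group on this ring would read also remains open.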